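A few compounds are considered here, and "the series" means these few. Any claim that something is new, unique, unknown or untested is made for them only; others in the source may bear on it.

Three measured compounds share one core. Compound 1, `O=C(Nc1cccc(-c2nc(-c3ccc(NC(=O)c4cccnc4)cc3Cl)no2)c1)c1ccccc1`, in a functional assay on MDA-MB-231 cells (Homo sapiens) for antiproliferative activity, read by MTT assay, with a stated time of 72 h (a lower number here means a stronger inhibitor, a higher number a weaker inhibitor), gives 12800 nM. Compound 2, `O=C(Nc1ccc(-c2noc(-c3cccc(NS(=O)(=O)c4ccccc4)c3)n2)c(Cl)c1)c1cccnc1`, reaches only the limit of the assay, > 10000 nM. Compound 3, `O=C(Nc1ccccc1)Nc1cccc(-c2nc(-c3ccc(NC(=O)c4cccnc4)cc3Cl)no2)c1`, likewise reaches only the limit, > 10000 nM. Because two of the three values sit at the limit (the limit of > 10000 nM in this assay, at which 2 of the 3 values shown sit), none of the three steps among them can be read: the step from compound 1 to compound 2, a step that the limit leaves unreadable from compound 1 to compound 2, that from compound 1 to compound 3, a step that the limit leaves unreadable from compound 1 to compound 3, and that from compound 2 to compound 3, a step that the two limits leave unreadable from compound 2 to compound 3. So compound 3 stands at the weak end of what the assay reports, with no number of its own.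

Compound 4, `O=C(Nc1ccc(Cl)cc1)Nc1cccc(-c2nc(-c3ccc(NC(=O)c4cccnc4)cc3Cl)no2)c1`, differs from compound 3 by chloro in place of hydrogen on an aromatic carbon. Within the data shown here, no measured step bears on this change; all three are unreadable. The expected step in this assay from compound 3 to compound 4 is therefore a step that the limit leaves unreadable from compound 3 to compound 4, that is, no movement beyond the scatter. Compound 4 is expected to give about 15000 nM, between 5000 nM and 45000 nM, most likely again reported only as a limit.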

Compound 4, half-maximal inhibitory concentration: > 10000 nM
Compound 4 ended at the assay's limit; the forecaster's own chance of this, stated with the estimate: 70%; the middle value does not contradict the limit.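

In this assay, among these compounds, compound 4 gives > 10000 nM as a limit and not a number, so no step to it from compound 1, compound 2 or compound 3 can be read: the limit of > 10000 nM in this assay, at which 3 of the 4 values shown sit. Going by these compounds, whether adding the chloro changes activity at all remains open, as does how compound 2, compound 3 and compound 4 truly compare with compound 1.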